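The compounds below may be only part of what the source reports. "The series", "measured", "known", "first", "only" and "open" are said of these compounds alone.

Series notes. Three compounds on one core are measured in a functional assay on NCI-H292 cells (Homo sapiens) for cytotoxicity, read by MTT assay, with a stated time of 72 h, tested at 5 ug/mL; a higher number here means more inhibition of growth at the concentration tested, a lower number less inhibition of growth. Compound 1 `O=C1NC(=S)/C(=C/c2ccc(Cl)cc2)S1` gives 35.8%. Compound 3 `O=C1NC(=S)/C(=C/c2ccc(Cl)c(Cl)c2)S1` gives 35.8%; it comes from compound 1 by chloro in place of hydrogen on an aromatic carbon, and the step is no change at the digits printed from compound 1 to compound 3 (within the scatter). Compound 2 `O=C1NC(=S)/C(=C/c2ccccc2Cl)S1` gives 34.2%; the difference between the core of compound 1 and the core of compound 2 is not broken down here, the two having the same atoms joined differently. All three values lie within the scatter of one another, so no order among them is claimed.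

Compound 4 `O=C1NC(=S)/C(=C/c2c(Cl)cccc2Cl)S1` is not yet measured. It comes from compound 2 by chloro in place of hydrogen on an aromatic carbon. This is the same kind of change as that from compound 1 to compound 3, not the same: there the entering chloro sat ortho to a chloro group and meta to a group of 8 heavy atoms, here it sits ortho to a group of 8 heavy atoms and meta to a chloro group. For the measured compounds named here, the only footing is the single earlier instance, no change at the digits printed from compound 1 to compound 3 (within the scatter). On that footing the step from compound 2 to compound 4 is expected to be a number 0.8 percentage points higher from compound 2 to compound 4 (within the scatter), the different placing adding uncertainty. Compound 4 is therefore expected to give 35% in this assay, within 24% to 46%.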

Compound 4, percent growth inhibition at one concentration: 10.3%
Compound 4: middle estimate off by 24.7 percentage points, on the high side; measured number outside the range, below it.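

In this assay, chloro in place of hydrogen on an aromatic carbon does not carry over from one core to another as a step of one size: the same change on two cores in this assay, no change at the digits printed (within the scatter) from compound 1 to compound 3 and a number 23.9 percentage points lower (beyond the scatter) from compound 2 to compound 4, 23.9 percentage points apart, beyond the scatter of two such steps

The new step, a number 23.9 percentage points lower from compound 2 to compound 4 (beyond the scatter), has the chloro entering ortho to a group of 8 heavy atoms and meta to a chloro group, and it shows that the earlier step gives no safe estimate for this placing. It does not show which difference between the two instances sets the steps apart, whether the placing of the entering chloro or the core it enters, and two instances support no rule for the series.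

The compounds shown carry only chloro or hydrogen on the aromatic ring, which leaves open how a methoxy group, an amine or a carboxylic acid would read in the same place. Also open, from the compounds shown here alone, is whether a smaller group such as fluoro, entering in the place of the chloro in compound 4, would give a step of similar size.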